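From compound 1 to compound 3: adding a methoxy group

This account rests on a few compounds, and the source may have more. Where it says the series, first, only, none or still open, it means among the compounds named here.

In a functional assay on HeLa cells (Homo sapiens) for cytotoxicity (a higher number here means a weaker inhibitor, a lower number a stronger inhibitor), compound 1 (`CC1=CCC[C@H]2[C@](C)(CC3=CC(=O)C=CC3=O)[C@@H](C)CC[C@]12C`) gives 26800 nM as its half-maximal inhibitory concentration. Among the compounds with values here, only one close relative has a number so far: compound 2 (`CC1=CCC[C@H]2[C@](C)(CC3=CC(=O)C(Sc4ccccc4)=CC3=O)[C@@H](C)CC[C@]12C`) gives 45000 nM in this assay and carries phenylsulfanyl in place of hydrogen on a double-bonded ring carbon. Within the data shown here, the step between them is a 1.7-fold higher number from compound 1 to compound 2 (0.23 log units; within the scatter) and so the two numbers cannot be told apart, which leaves compound 1 level with its only measured neighbour.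

Compound 3 (`COC1=CC(=O)C=C(C[C@]2(C)[C@@H](C)CC[C@]3(C)C(C)=CCC[C@@H]23)C1=O`) has not been measured yet. It differs from compound 1 by methoxy in place of hydrogen on a double-bonded ring carbon. Among the measured compounds shown here, the one measured swap of this kind is the step of a 1.7-fold higher number from compound 1 to compound 2 (0.23 log units; within the scatter) and it is the only guide available. Methoxy is a different group and a single step is thin evidence, yet nothing here points to a real shift, so no step beyond the scatter is expected in this assay in either direction. The estimated step is a 1.1-fold higher number from compound 1 to compound 3 (0.05 log units; within the scatter) and that is a small one. For compound 3 the expected value is 30000 nM with 12000 nM and 70000 nM as the estimated ends of the range.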

Compound 3, half-maximal inhibitory concentration: 13300 nM
Estimate against measurement, compound 3: 2.3-fold (0.35 log units) above; the measured number falls inside the stated range.
By their numbers in this assay, from the lowest: compounds 3, 1 and 2 (each within the scatter of the next, the first and the last beyond it).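

In this assay, methoxy in place of hydrogen on a double-bonded ring carbon gives a 2.0-fold lower number from compound 1 to compound 3 (0.30 log units; within the scatter), so compound 3 and compound 1 cannot be told apart. Until now, the only replacement of a hydrogen on a double-bonded ring carbon of this ring was the phenylsulfanyl group of compound 2, which gives a 1.7-fold higher number from compound 1 to compound 2 (0.23 log units; within the scatter); methoxy, at a carbon two ring bonds from the ring atom that bears a large group, now adds a second group that leaves the number within the scatter of compound 1, and the two results together are the whole of what is known about such replacements. No measurement is available that explains this result.

As far as these compounds go, whether any group on this carbon can move the number beyond the scatter of compound 1 remains open, since an amine, a carboxylic acid or a longer chain such as ethoxy in place of the methoxy group could behave differently. Also open, from the compounds shown here alone, is whether a second methoxy group elsewhere on the same ring would add anything to the result for compound 3.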